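A few compounds are considered here, and "the series" means these few. Any claim that something is new, unique, unknown or untested is made for them only; others in the source may bear on it.

Three compounds have been measured so far:

compound 1 `Cn1c(-c2ccc(F)cc2)nc2c(NC3CCCC3)ncnc21`: 1140 nM
compound 2 `CCCn1c(-c2ccccc2)nc2c(NC3CCOC3)ncnc21`: 2810 nM
compound 3 `CCCn1c(-c2ccccc2)nc2c(NC3CCCCC3)ncnc21`: 2360 nM

In an assay on CHO cells for displacement of a labelled ligand from adenosine receptor A3 (Homo sapiens), read by scintillation counting, with a stated time of 3 h (a higher number here means a weaker inhibitor, a lower number a stronger inhibitor), compound 1 gives the lowest of the three numbers and is therefore the strongest inhibitor among them; compound 2 and compound 3 both give higher numbers, each beyond the usual scatter. Among the measured compounds shown here, the only measured step that changes a single place, a 1.2-fold lower number from compound 2 to compound 3 (0.08 log units; within the scatter), alters the ring attached to the nitrogen on the core and leaves the aryl group untouched. Compound 4 `Cn1c(-c2ccccc2Cl)nc2c(NC3CCCC3)ncnc21` differs from compound 1 by 2-chlorophenyl in place of 4-fluorophenyl on an aromatic carbon. For the measured compounds named here, no measured step touches this part of the molecule, so nothing here indicates the size or direction of the change, and the expectation rests on compound 1 alone with wide uncertainty. The change is expected to amount to a 1.3-fold higher number from compound 1 to compound 4 (0.12 log units; within the scatter), which is not beyond the scatter. Compound 4 is therefore estimated at 1500 nM, within a range of 400 nM to 6000 nM.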

Compound 4, inhibition constant: 720 nM
The estimate for compound 4 lay 2.1-fold (0.32 log units) above the measured number; measured number inside the range.
By their numbers in this assay, from the lowest: compounds 4 and 1 (each within the scatter of the next); then compounds 3 and 2 (each within the scatter of the next).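

In this assay, among the compounds shown here, the first measured change at this position, 2-chlorophenyl in place of 4-fluorophenyl on an aromatic carbon, gives a 1.6-fold lower number from compound 1 to compound 4 (0.20 log units; within the scatter). Because this difference lies within the scatter, the two compounds cannot be told apart, so at this position and in this pair, the exchange of one halogen-bearing phenyl for the other leaves no measurable mark on the number. No measurement shown here offers an explanation for this result.

On these data alone, this single step changes both the halogen and its place on the phenyl ring, so the effect of each alone remains unknown. Still open, as far as these compounds go, is how 4-chlorophenyl or 2-fluorophenyl would behave on the same core, and whether a larger change, such as a methoxy group or an amine on the phenyl ring, would move the number beyond the scatter.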